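One more methoxy on a dimethoxyphenyl group

The compounds below may be only part of what the source reports. "The series", "measured", "known", "first", "only" and "open" are said of these compounds alone.

In a functional assay on CNE-2 cells (Homo sapiens) for antiproliferative activity, read by sulforhodamine B assay, with a stated time of 48 h (a higher number here means a weaker inhibitor, a lower number a stronger inhibitor), compound 1 `COc1ccc(C=C(C(=O)/C=C/c2cccc(OC)c2OC)C(=O)/C=C/c2cccc(OC)c2OC)cc1OC` gives 280 nM and compound 2 `COc1cccc(C=C(C(=O)/C=C/c2cccc(OC)c2OC)C(=O)/C=C/c2cccc(OC)c2OC)c1OC` gives 400 nM with the two values within the scatter of each other. The change to compound 3 `COc1cccc(/C=C/C(=O)C(=Cc2ccc(OC)c(OC)c2OC)C(=O)/C=C/c2cccc(OC)c2OC)c1OC` is methoxy in place of hydrogen on an aromatic carbon and amounts to methoxy in place of hydrogen on an aromatic carbon, turning 2,3-dimethoxyphenyl into 2,3,4-trimethoxyphenyl. Among the measured compounds shown here, the one measured step of a 1.4-fold higher number from compound 1 to compound 2 (0.15 log units; within the scatter) exchanges 3,4-dimethoxyphenyl for 2,3-dimethoxyphenyl and adds no methoxy, so it offers only limited guidance. Nothing beyond the scatter is therefore expected in this assay for this change. The expected step is a 1.1-fold lower number from compound 2 to compound 3 (0.06 log units; within the scatter) in size. For compound 3 the estimated value is 350 nM and 130 nM to 900 nM is its expected range.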

Compound 3, half-maximal inhibitory concentration: 410 nM
Beside the measured number, compound 3's estimate is 1.2-fold (0.07 log units) below it; the measured number falls inside the stated range.
By their numbers in this assay, from the lowest: compounds 1, 2 and 3 (each within the scatter of the next).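

In this assay, methoxy in place of hydrogen at the carbon para to a large group, turning 2,3-dimethoxyphenyl into 2,3,4-trimethoxyphenyl, gives a 1.0-fold higher number from compound 2 to compound 3 (0.01 log units; within the scatter). This position therefore accepts a third methoxy with no step beyond the scatter, and a 1.5-fold higher number from compound 1 to compound 3 (0.17 log units; within the scatter) also stays within it. Nothing available here offers an explanation for this result. Still open is whether an amine or a carboxylic acid at this carbon would also stay within the scatter, since methoxy is the only group shown there.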